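The compounds below may be only part of what the source reports. "The series", "measured", "known", "first", "only" and "open" are said of these compounds alone.

Compound 2 `FC(F)(F)Oc1ccc(Cn2cc(CCCOc3cccc4cccnc34)nn2)cc1` carries a trifluoromethoxy group on the aromatic ring at the end of the chain. In an ADME assay on HaCaT cells (Homo sapiens) for inhibition, read by sulforhodamine B assay, with a stated time of 48 h (on this read-out lower numbers stand for stronger inhibition of growth and higher numbers for weaker inhibition of growth), compound 2 gives 4 ug/mL, the lower of the two numbers recorded so far. Its nearest neighbour is compound 1 `Fc1ccc(Cn2cc(CCCOc3cccc4cccnc34)nn2)cc1`, which differs only in having fluoro in place of the trifluoromethoxy group; in this assay compound 1 gives 115 ug/mL. Going by the values given here, the one measured step between them, a 29-fold lower number from compound 1 to compound 2 (1.46 log units; beyond the scatter), is large and beyond the scatter.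

Compound 3 `c1ccc(Cn2cc(CCCOc3cccc4cccnc34)nn2)cc1` is not yet measured in this assay. It differs from compound 2 by hydrogen in place of trifluoromethoxy on an aromatic carbon. Among the compounds with values here, the only step that bears on this change is the one from compound 1 to compound 2, where exchanging fluoro for trifluoromethoxy lowered the number sharply. Taking the trifluoromethoxy group away altogether is expected to move the number back up, toward where compound 1 stands or somewhat past it. Compound 3 is therefore estimated to give about 100 ug/mL in this assay, within a range of 30 ug/mL to 300 ug/mL, a step of a 25-fold higher number from compound 2 to compound 3 (1.40 log units; beyond the scatter).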

Compound 3, concentration for 50% growth inhibition: 12.7 ug/mL
Beside the measured number, compound 3's estimate is 7.9-fold (0.90 log units) above it, and the stated range ends above it.
By their numbers in this assay, from the lowest: compound 2; then compound 3; then compound 1.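

Compound 3 gives this position a reference point with hydrogen on the aromatic carbon para to a large group, which the pair of compound 1 and compound 2 could not provide, since that pair showed only the gap between two substituents. In this assay, the two substituents turn out to act in opposite directions: hydrogen in place of trifluoromethoxy gives a 3.2-fold higher number from compound 2 to compound 3 (0.50 log units; beyond the scatter), so trifluoromethoxy goes with stronger inhibition of growth than hydrogen, while hydrogen in place of fluoro gives a 9.1-fold lower number from compound 1 to compound 3 (0.96 log units; beyond the scatter), so fluoro goes with weaker inhibition than hydrogen, and the larger part of the gap between compound 1 and compound 2 therefore lies on the fluoro side. Nothing available here accounts for why these two groups pull in opposite directions.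

The compounds shown leave open where a methoxy, a chloro or a trifluoromethyl group on this carbon would fall relative to hydrogen, and whether an amine would follow either direction. They also leave open whether fluoro and trifluoromethoxy would keep these opposite directions on another carbon of the same ring.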